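Compound 3 to compound 4: tert-butyl for methoxy

The source may hold more compounds than are shown below. What is called first, only, known or untested is meant among the compounds shown, and "the series" means these compounds.

In a functional assay on HCT-116 cells (Homo sapiens) for inhibition, read by CCK-8 assay, with a stated time of 48 h (on this read-out lower numbers stand for stronger inhibition and higher numbers for weaker inhibition), compound 1 (`COc1cc(-c2ccnc3cc(-c4ccc(C)c(C)c4)nn23)cc(OC)c1OC`) gives 261 nM, compound 2 (`COc1cc(-c2ccnc3cc(-c4cccc(C)c4)nn23)cc(OC)c1OC`) gives 6150 nM and compound 3 (`COc1ccc(-c2cc3nccc(-c4cc(OC)c(OC)c(OC)c4)n3n2)cc1`) gives 404 nM. Compound 3 thus lies within the scatter of compound 1 and far under compound 2.

Compound 4 (`COc1cc(-c2ccnc3cc(-c4ccc(C(C)(C)C)cc4)nn23)cc(OC)c1OC`) carries tert-butyl in place of methoxy on an aromatic carbon, para to a large group: tert-butyl in place of methoxy on an aromatic carbon.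

Going by the values given here, three steps bear on this change. Hydrogen in place of methyl gave a large change, a 24-fold higher number from compound 1 to compound 2 (1.37 log units; beyond the scatter), and 4-methoxyphenyl in place of 3-methylphenyl gave another, a 15-fold lower number from compound 2 to compound 3 (1.18 log units; beyond the scatter). Only compound 2 has hydrogen at this place. Exchanging one group there for another, in a 1.5-fold higher number from compound 1 to compound 3 (0.19 log units; within the scatter), stayed within the scatter. Among the compounds with values here, compound 4 keeps a group at this place, so no large step is expected, but no measured compound carries tert-butyl and the range stays wide.

The expected change is a 1.2-fold higher number from compound 3 to compound 4 (0.09 log units; within the scatter), not beyond the scatter. For compound 4 the estimated value is 500 nM, with an expected range of 150 nM to 2500 nM.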

Compound 4, half-maximal inhibitory concentration: > 10000 nM
Compound 4: only a limit was reported (the forecaster's own chance of this, stated with the estimate: 3%); at least 20-fold (1.30 log units) between middle value and limit.
By their numbers in this assay, from the lowest: compounds 1 and 3 (each within the scatter of the next); then compound 2. At a limit, above all of these: compound 4.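

In this assay compound 4 reaches only a limit of the read-out, not a number: the limit of > 10000 nM in this assay, at which 1 of the 4 values shown sits. The earlier exchange at this place stayed within the scatter (a 1.5-fold higher number from compound 1 to compound 3 (0.19 log units; within the scatter)), but tert-butyl in place of methoxy gives a large step (an at least 24-fold higher number from compound 3 to compound 4 (1.39 log units; beyond the scatter)), as does the comparison with the dimethylphenyl compound (an at least 38-fold higher number from compound 1 to compound 4 (1.58 log units; beyond the scatter)), so keeping a group at this place does not by itself hold the number. The floor against the 3-methylphenyl compound lies within the scatter (an at least 1.6-fold higher number from compound 2 to compound 4 (0.21 log units; that floor lies within the scatter)), so that pair stays unordered.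

Open, as far as these compounds go, is whether the step follows the loss of methoxy or the arrival of tert-butyl, as one exchange changes both. Also open, from the compounds shown here alone, is how ethyl, isopropyl, hydroxyl or an amine at this place would read.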